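Hydroxy to Trifluoromethoxy: Estimating One Untested Step

A few compounds are considered here, and "the series" means these few. Any claim that something is new, unique, unknown or untested is made for them only; others in the source may bear on it.

Compound 1 `O=C(Cc1cccnc1)c1cc2cc([N+](=O)[O-])ccc2[nH]1`: "not active" (no number reported)
Compound 2 `O=C(Cc1cccnc1)c1cc2cc(O)ccc2[nH]1`: 37000 nM

Of the compounds shown here, two on a shared core have been tested in an assay on isolated protein for inhibition of Indoleamine 2,3-dioxygenase 1 (Homo sapiens), read by spectrophotometry; on this read-out lower numbers stand for stronger inhibition and higher numbers for weaker inhibition. For compound 1 this assay gives "not active" (no number reported), with no single number reported. For the measured compounds named here, compound 2 gives 37000 nM in this assay, and so it stands as the only compound with a number at all; it is a weak inhibitor, and there is no second number to rank it against.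

Compound 3 `O=C(Cc1cccnc1)c1cc2cc(OC(F)(F)F)ccc2[nH]1` has not been measured. It differs from compound 2 by trifluoromethyl in place of hydrogen on an oxygen on an aromatic ring. Going by the values given here, no step between two measured compounds is available to calibrate this change, and compound 1, the other measured entry, carries no number. The expectation for compound 3 therefore rests on compound 2 alone, with wide uncertainty; a step of a 1.6-fold higher number from compound 2 to compound 3 (0.21 log units; within the scatter) toward weaker inhibition is expected. Compound 3 is estimated at 60000 nM, with a range from 15000 nM to 250000 nM.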

Compound 3, half-maximal inhibitory concentration: 13100 nM
Beside the measured number, compound 3's estimate is 4.6-fold (0.66 log units) above it; the whole stated range lies above it.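

In this assay, for the compounds shown here, the change from hydroxy to trifluoromethoxy gives a 2.8-fold lower number from compound 2 to compound 3 (0.45 log units; beyond the scatter), the first step on this shared core that can be read as a number. It shows that the hydrogen on this oxygen is not needed for measurable inhibition, since compound 3 keeps a number with trifluoromethyl in its place, and that the number moves toward stronger inhibition, though only modestly. Nothing shown explains why the number falls.

The compounds shown leave open whether the step belongs to the trifluoromethyl itself or would also appear with a plain methoxy, an ethoxy chain or a single fluorine atom at this place. They also leave open how an amine or a carboxylic acid there would compare with compound 2 and compound 3.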